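The source may hold more compounds than are shown below. What is called first, only, known or untested is meant among the compounds shown, and "the series" means these compounds.

Values in an ADME assay on ECV-304 cells (Homo sapiens) for cytotoxicity, read by MTT assay, with a stated time of 72 h; on this read-out lower numbers stand for stronger inhibition and higher numbers for weaker inhibition:

Compound 1 `COc1ccc(C2=C(c3cc(OC)c(OC)c(OC)c3)C(=O)CC2O[SiH2]C(C)(C)C)cc1`: > 100 ug/mL (a limit)
Compound 2 `COc1ccc(C2=C(c3cc(OC)c(OC)c(OC)c3)C(=O)CC2O)cc1O`: > 100 ug/mL (a limit)
Compound 3 `COc1cc(C2=C(c3ccc(OCC(=O)O)cc3)C(O)CC2=O)cc(OC)c1OC`: "not determined" (no result reported)

Compound 3 has no place on the scale of this assay. Its entry, "not determined" (no result reported), means that no result was reported, so it offers no number to start from. Going by the values given here, the only other readings in the set are limits and not numbers. Compound 1 reads > 100 ug/mL, which is a limit of the assay. Compound 2 reads > 100 ug/mL, which is also a limit.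

Compound 4 `COc1ccc(C2=C(c3cc(OC)c(OC)c(OC)c3)C(=O)CC2O)cc1` has yet to be measured. The structural change that leads to it is hydrogen in place of carboxy on a saturated chain carbon bound to an oxygen on an aromatic ring. Cut one bond further out, the same difference reads carboxymethoxy to methoxy.

Among the compounds with values here, since compound 3 has no value, the size of this step cannot be read from the data, and no measured step between related compounds is available as a guide. Within the data shown here, the only guide is the limit of > 100 ug/mL in this assay, at which 2 of the 3 values shown sit. On that basis, no clear move away from this limit is expected in this assay, and no direction can be assigned, so compound 4 will quite possibly be reported as a limit too. For compound 4 the estimated value is 100 ug/mL, with an expected range from 40 ug/mL to 150 ug/mL.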

Compound 4, half-maximal inhibitory concentration: > 100 ug/mL
Compound 4 was reported as a limit; the forecaster's own chance of this, stated with the estimate: 75%; the middle value sits exactly at the limit.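

In this assay compound 4 gives > 100 ug/mL, which is a limit of the assay and not a number. Going by these compounds alone, compound 1 and compound 2 also read as limits, so no step from either of them to compound 4 can be read. The compounds shown leave open where any of them falls on this scale: the limit of > 100 ug/mL in this assay, at which 3 of the 4 values shown sit.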